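The source may hold more compounds than are shown below. What is called first, only, known or untested is meant among the compounds shown, and "the series" means these compounds.

Measured in an ADME assay on MT4 cells (Homo sapiens) for cytotoxicity, read by MTT assay; on this read-out lower numbers stand for higher toxicity in this test and higher numbers for lower toxicity in this test:

Compound 1 `Cc1ccc(NC(=O)CSc2nncnc2-c2cccc3ccccc23)c(Br)c1`: 166000 nM
Compound 2 `O=C(CSc1nncnc1-c1cccc2ccccc12)Nc1ccccc1`: 154000 nM
Compound 3 `Cc1ccc(NC(=O)CSc2nncnc2-c2cccc3ccccc23)c([N+](=O)[O-])c1`: 147000 nM

Compound 1 stands level with the other two compounds, since all three values lie within the scatter of one another. Compound 4 `NS(=O)(=O)c1ccc(NC(=O)CSc2nncnc2-c2cccc3ccccc23)c(Br)c1` carries sulfamoyl in place of methyl on an aromatic carbon of compound 1 (sulfamoyl in place of methyl on an aromatic carbon).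

Going by the values given here, no measured compound carries sulfamoyl, so the evidence is indirect. Replacing 2-bromo-4-methylphenyl with phenyl on the amide-type nitrogen, which removes the methyl along with the bromo, gave a 1.1-fold lower number from compound 1 to compound 2 (0.03 log units; within the scatter). Nitro in place of bromo gave a 1.1-fold lower number from compound 1 to compound 3 (0.05 log units; within the scatter), and 4-methyl-2-nitrophenyl in place of phenyl gave a 1.0-fold lower number from compound 2 to compound 3 (0.02 log units; within the scatter). All three steps are small, so no step beyond the scatter is expected in this assay, though sulfamoyl is a larger and untested change, which widens the range. The expected step is a 1.1-fold lower number from compound 1 to compound 4 (0.04 log units; within the scatter). The estimate for compound 4 is 150000 nM, with an expected range from 60000 nM to 320000 nM.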

Compound 4, half-maximal cytotoxic concentration: 23000 nM
The estimate for compound 4 lay 6.5-fold (0.81 log units) above the measured number, outside the stated range (below it).
By their numbers in this assay, from the lowest: compound 4; then compounds 3, 2 and 1 (each within the scatter of the next).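

In this assay, going by these compounds alone, sulfamoyl in place of methyl on this aromatic carbon, para to a large group and meta to the bromo group, gave a 7.2-fold lower number from compound 1 to compound 4 (0.86 log units; beyond the scatter) and so produced the first step beyond the scatter in this small set. The earlier compounds shown here, all level with one another, gave no sign that the number could move at all with changes on this ring. Compound 2, which lacks both the methyl and the bromo, stayed within the scatter of compound 1, so the loss of the methyl alone does not appear to account for the step. Nothing shown here explains the step.

As far as these compounds go, whether an amine, a carboxylic acid or a methylsulfonyl group on this carbon would give a similar step remains open. So does whether the step depends on the bromo group, since sulfamoyl appears here only alongside it.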